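Urea aryl variation on the shared core: compound 4

The compounds below may be only part of what the source reports. "The series", "measured", "known", "first", "only" and "open" are said of these compounds alone.

Compound 2 `O=C(Nc1cccc(Cl)c1)Nc1nnc(Sc2ncnc3scc(-c4ccncc4)c23)s1` in a functional assay on HepG2 cells (Homo sapiens) for antiproliferative activity, read by MTT assay, with a stated time of 48 h (a higher number here means a weaker inhibitor, a lower number a stronger inhibitor), gives 22900 nM. The three measured numbers sit within the scatter of one another: compound 1 `O=C(Nc1ccccc1)Nc1nnc(Sc2ncnc3scc(-c4ccncc4)c23)s1` gives 19400 nM and compound 3 `O=C(Nc1ccc(Cl)cc1)Nc1nnc(Sc2ncnc3scc(-c4ccncc4)c23)s1` gives 28900 nM, and the steps of a 1.2-fold higher number from compound 1 to compound 2 (0.07 log units; within the scatter), a 1.5-fold higher number from compound 1 to compound 3 (0.17 log units; within the scatter) and a 1.3-fold higher number from compound 2 to compound 3 (0.10 log units; within the scatter) all stay within the scatter. Compound 4 `O=C(Nc1ccc(Cl)c(C(F)(F)F)c1)Nc1nnc(Sc2ncnc3scc(-c4ccncc4)c23)s1` differs from compound 2 by 4-chloro-3-(trifluoromethyl)phenyl in place of 3-chlorophenyl on an amide-type nitrogen. Among the compounds with values here, no measured step introduces a trifluoromethyl; the only steps that bear on the change are the two chloro additions and the chloro relocation, none of which moved this assay beyond the scatter. No step beyond the scatter is therefore expected for compound 4. The estimate for compound 4 in this assay is 25000 nM, with a range of 10000 nM to 60000 nM. The expected step is a 1.1-fold higher number from compound 2 to compound 4 (0.04 log units; within the scatter).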

Compound 4, half-maximal inhibitory concentration: 45300 nM
Compound 4: the middle estimate sits 1.8-fold (0.26 log units) below what was measured; the range from low to high includes it.
By their numbers in this assay, from the lowest: compounds 1, 2, 3 and 4 (each within the scatter of the next, the first and the last beyond it).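

In this assay trifluoromethyl in place of hydrogen on the 4-chlorophenyl gives (a 1.6-fold higher number from compound 3 to compound 4 (0.20 log units; within the scatter)), and 4-chloro-3-(trifluoromethyl)phenyl in place of 3-chlorophenyl gives (a 2.0-fold higher number from compound 2 to compound 4 (0.30 log units; within the scatter)), so neither step separates compound 4 from its single-chloro neighbours. Only against the plain phenyl does a step leave the scatter (a 2.3-fold higher number from compound 1 to compound 4 (0.37 log units; beyond the scatter)), and that step is modest and carries both substituents at once. No measurement here accounts for it. Open, as far as these compounds go, is whether trifluoromethyl without the chloro gives the same step. Also open, from the compounds shown here alone, is what an amine or a carboxylic acid on this phenyl would do in this assay.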